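Chloro to methyl on the indazole of the urea series

The compounds below may be only part of what the source reports. "The series", "measured", "known", "first", "only" and "open" are said of these compounds alone.

Of the compounds shown here, two have been measured in a functional assay on OS-RC-2 cells (Homo sapiens) for cytotoxicity, read by MTT assay, with a stated time of 72 h; a higher number here means a weaker inhibitor, a lower number a stronger inhibitor. Compound 1 `O=C(Nc1ccc(-n2ncc3c(Cl)cccc32)cc1)Nc1ccc(Cl)c(C(F)(F)F)c1` gives 3100 nM and stands as the lower of the two numbers, with compound 2 `O=C(Nc1ccc(-n2ncc3c(F)cccc32)cc1)Nc1ccc(Cl)c(C(F)(F)F)c1` the nearest, at a higher number. In this assay compound 2 gives 32000 nM. Going by the values given here, the single step measured so far is a 10-fold higher number from compound 1 to compound 2 (1.01 log units; beyond the scatter), a large change at the same position of the shared core.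

Compound 3 `Cc1cccc2c1cnn2-c1ccc(NC(=O)Nc2ccc(Cl)c(C(F)(F)F)c2)cc1` differs from compound 1 by methyl in place of chloro on an aromatic carbon. Among the compounds with values here, no measured step covers methyl at this position; the only bearing on it is the step from compound 1 to compound 2, which shows that exchanging the chloro at this site for a smaller halogen costs a large amount. Methyl is not a halogen, so that step is only an indirect guide, and the direction for compound 3 is uncertain, with a modest loss considered somewhat more likely than a gain.

The expected outcome for compound 3 is 6000 nM, within 2000 nM to 20000 nM, meaning an estimated step of a 1.9-fold higher number from compound 1 to compound 3 (0.29 log units; within the scatter).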

Compound 3, half-maximal inhibitory concentration: 32000 nM
Beside the measured number, compound 3's estimate is 5.3-fold (0.73 log units) below it; the whole stated range lies below it.
By their numbers in this assay, from the lowest: compound 1; then compounds 2 and 3 (each within the scatter of the next).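

The change from 4-chloro-1H-indazol-1-yl to 4-methyl-1H-indazol-1-yl gives a 10-fold higher number from compound 1 to compound 3 (1.01 log units; beyond the scatter) in this assay, so the large loss at this position now appears with a non-halogen replacement as well as with fluoro. Going by these compounds alone, the two replacements also coincide, with no change at the digits printed from compound 2 to compound 3 (within the scatter), leaving compound 1 at 3100 nM as the only one of the three compounds set apart at this site, with both of its steps beyond the scatter. With only chloro, fluoro and methyl compared, the data give no explanation for this separation, and no supporting measurement bears on its cause.

Still open, as far as these compounds go, is whether another group at this position, such as bromo, methoxy, nitrile or an amine, can match or improve on chloro in this assay, which would show whether the chloro result is isolated or part of a wider trend. From the compounds shown here alone, it also remains open whether the same sensitivity to the chloro group holds when the chloro and trifluoromethyl groups on the other aromatic ring of the urea are replaced.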